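Solubility notes on a phenylethynyl-benzamide hydroxamate series

The source may report more compounds than this note shows. Statements on the series, on what has been measured and on what is new or still open speak of the compounds shown alone.

Measured so far:
compound 1, `COCCNC(=O)C[C@H](NC(=O)c1ccc(C#Cc2ccccc2)cc1)C(=O)NO`: 78000 nM
compound 2, `CC(C)(NC(=O)c1ccc(C#Cc2ccccc2)cc1)C(=O)NO`: 182000 nM

In a physicochemical assay for solubility (on this read-out higher numbers stand for higher solubility and lower numbers for lower solubility), compound 1 gives 78000 nM, the lower of the two numbers. Compound 2 gives 182000 nM, a gap beyond the usual scatter, so compound 1 stands at the low end of what is known here. Compound 3 `CS(=O)(=O)C[C@H](NC(=O)c1ccc(C#Cc2ccccc2)cc1)C(=O)NO` has not been measured in this assay. It differs from compound 1 by methylsulfonyl in place of (2-methoxyethyl)carbamoyl on a saturated chain carbon, two bonds along the chain from an amide-type nitrogen and a carbonyl carbon. Going by the values given here, no measured pair shows this change, so its effect is open. The step of a 1.3-fold higher number from compound 1 to compound 3 (0.11 log units; within the scatter) is expected to be small, probably not beyond the scatter, perhaps slightly upward. Compound 3 is estimated at 100000 nM, with a range from 40000 nM to 250000 nM.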

Compound 3, solubility: 2000 nM
Beside the measured number, compound 3's estimate is 50-fold (1.70 log units) above it; the whole stated range lies above it.
By their numbers in this assay, from the lowest: compound 3; then compound 1; then compound 2.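

In this assay, methylsulfonyl in place of (2-methoxyethyl)carbamoyl on this saturated chain carbon gives a 39-fold lower number from compound 1 to compound 3 (1.59 log units; beyond the scatter) and is a large step, beyond the scatter. This position is therefore not indifferent to the group it carries, and the read-out can move far with this one change. Nothing measured here accounts for the drop. Open, from the compounds shown here alone, is whether the step follows from methylsulfonyl entering or from (2-methoxyethyl)carbamoyl leaving. A carboxylic acid, an amine or a longer chain ending in methylsulfonyl on this carbon would help separate the two.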